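Compound 3: hydrogen in place of methoxy

The source may hold more compounds than are shown below. What is called first, only, known or untested is meant among the compounds shown, and "the series" means these compounds.

Measured so far in an ADME assay for metabolic stability, at pH 3.0; on this read-out higher numbers stand for a longer-lived compound and lower numbers for a shorter-lived compound:
- compound 1 (`COc1ccc2c(c1)COP(=O)(OC[C@@H]1C=C[C@H](n3cnc4c(N)ncnc43)O1)O2`) gives 0.14 h as its half-life
- compound 2 (`Cc1cccc2c1OP(=O)(OCC1CC(O)C(n3cnc4c(O)ncnc43)O1)OC2`) gives 0.04 h as its half-life

Compound 1 stands highest of these two numbers, and the gap to compound 2 lies beyond the scatter. Going by the values given here, that gap is the whole of the present picture, since no pair of measured compounds differs in one place only.

The next compound to be read is compound 3 (`Nc1ncnc2c1ncn2[C@H]1C=C[C@@H](COP2(=O)OCc3ccccc3O2)O1`), which has hydrogen in place of methoxy on an aromatic carbon. The rest of the core of compound 1 stays as it is. The series holds no measured case of this exchange, so its size cannot be read from any earlier step.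

Among the compounds with values here, the only anchor is compound 1 at 0.14 h in this assay, and no step beyond the scatter is expected there, with no direction favoured. The estimated no change at the digits printed from compound 1 to compound 3 (within the scatter) is expected to stay within the scatter. With so little support, the range is kept broad. Expected for compound 3 is 0.14 h (estimated range 0.07 h to 0.28 h).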

Compound 3, half-life: 0.14 h
For compound 3 middle estimate and measured number coincide at the digits printed; measured number inside the range.
By their numbers in this assay, from the lowest: compound 2; then compounds 1 and 3 (each within the scatter of the next).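

In this assay, going by these compounds alone, hydrogen in place of methoxy on an aromatic carbon gives no change at the digits printed from compound 1 to compound 3 (within the scatter) in the first single-place step. The position lies on the six-membered aromatic ring of carbon only, part of a fused or bridged system of two rings, and this step shows that the half-life of the core of compound 1 is held with either methoxy or hydrogen there, so the methoxy is not needed to keep the read-out of compound 1 in this assay. No measured property bears on why the two compounds read alike.

On these data alone, one exchange at one position gives only a narrow view: whether an amine, a carboxylic acid, fluorine or a longer alkoxy chain at the same aromatic carbon would also leave the half-life in place remains open. Also open, as far as these compounds go, is whether hydrogen in place of methoxy reads the same way on a different core, and whether other positions on this aromatic ring respond to such exchanges as this one does.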